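The source may hold more compounds than are shown below. What is called first, only, known or untested is meant among the compounds shown, and "the series" means these compounds.

In an ADME assay on MT4 cells (Homo sapiens) for cytotoxicity, read by MTT assay (on this read-out higher numbers stand for lower toxicity in this test and lower numbers for higher toxicity in this test), compound 3 `O=C1c2ccccc2C(=O)N1CCOC(=S)N(C(=O)c1ccc(F)c(F)c1)c1ccc(Cl)cc1` gives 52000 nM and compound 2 `O=C1c2ccccc2C(=O)N1CCOC(=S)N(C(=O)c1c(F)cccc1F)c1ccc(Cl)cc1` gives 39000 nM. Among the measured compounds shown here, these are the only exact numbers so far, and they lie within the scatter of each other. Compound 1 `O=C1c2ccccc2C(=O)N1CCOC(=S)N(C(=O)c1ccc([N+](=O)[O-])cc1)c1ccc(Cl)cc1` reaches only a limit of the assay, > 100000 nM.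

Compound 4 `O=C1c2ccccc2C(=O)N1CCOC(=S)N(C(=O)c1ccc(Cl)cc1Cl)c1ccc(Cl)cc1` differs from compound 3 by 2,4-dichlorophenyl in place of 3,4-difluorophenyl on a carbonyl carbon. The closest guide is a 1.3-fold higher number from compound 2 to compound 3 (0.12 log units; within the scatter), which also exchanges one aromatic group on the carbonyl carbon for another. The other two steps, an at least 2.5-fold lower number from compound 1 to compound 2 (0.40 log units; beyond the scatter) and an at least 1.9-fold lower number from compound 1 to compound 3 (0.28 log units; that floor lies within the scatter), start from that limit and show only floors. No change beyond the scatter is therefore expected, and the estimated step is a 1.2-fold lower number from compound 3 to compound 4 (0.06 log units; within the scatter). Compound 4 is expected at 45000 nM, with an estimated range of 20000 nM to 95000 nM.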

Compound 4, half-maximal cytotoxic concentration: 18000 nM
Compound 4: the middle estimate sits 2.5-fold (0.40 log units) above what was measured; the whole stated range lies above it.
By their numbers in this assay, from the lowest: compound 4; then compounds 2 and 3 (each within the scatter of the next). At a limit, above all of these: compound 1.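

In this assay, among the compounds shown here, compound 4 gives the first change beyond the scatter between exact values, with a 2.9-fold lower number from compound 3 to compound 4 (0.46 log units; beyond the scatter) and a 2.2-fold lower number from compound 2 to compound 4 (0.34 log units; beyond the scatter). The aromatic group on the carbonyl carbon can therefore shift toxicity in this test, whereas the two difluorophenyl compounds, compound 2 and compound 3, stayed within the scatter of each other. The remaining step, an at least 5.5-fold lower number from compound 1 to compound 4 (0.74 log units; beyond the scatter), is only a floor resting on a limit: the limit of > 100000 nM in this assay, at which 1 of the 4 values shown sits.

The compounds shown leave open whether the chlorine atoms themselves or their placement on the ring carries this step. They also leave open how a phenyl ring bearing a methoxy group, an amine or a carboxylic acid would read at this position.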